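Plasma stability on the path from compound 1 to compound 4

The source may hold more compounds than are shown below. What is called first, only, known or untested is meant among the compounds shown, and "the series" means these compounds.

Measured compounds
compound 1: `CC(C)OC(=O)c1cccc(NC(=O)[C@@H]2C[C@H](SC3=C(C(=O)O)N4C(=O)[C@H]([C@@H](C)O)[C@H]4[C@H]3C)CN2)c1` — "not determined" (no result reported)
compound 2: `CC(C)OC(=O)C1=C(S[C@@H]2CN[C@H](C(=O)Nc3cccc(C(=O)OC(C)C)c3)C2)[C@H](C)[C@@H]2[C@@H]([C@@H](C)O)C(=O)N12` — 0%
compound 3: `CCOC(=O)OCOC(=O)C1=C(S[C@@H]2CN[C@H](C(=O)Nc3cccc(C(=O)OCOC(=O)OCC)c3)C2)[C@H](C)[C@@H]2[C@@H]([C@@H](C)O)C(=O)N12` — 0%

The series was characterised in an ADME assay on a cell-free system (plasma, Rattus norvegicus) for metabolic stability, read by LC-MS, with a stated time of 60 min, at 37 degrees C, tested at 50 uM; on this read-out lower numbers stand for a less stable compound and higher numbers for a more stable compound. Compound 1 carries an isopropyl ester on the aryl amide side and a free carboxylic acid on the shared core; for compound 1 no single number is available in this assay. Compound 2, which carries two isopropyl esters, gives 0%. Compound 3, which carries two (ethoxycarbonyloxy)methyl esters, gives 0%. Both readings lie at the bottom of the scale, and neither differs from the other.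

Compound 4, `CC(C)C(=O)OCOC(=O)c1cccc(NC(=O)[C@@H]2C[C@H](SC3=C(C(=O)O)N4C(=O)[C@H]([C@@H](C)O)[C@H]4[C@H]3C)CN2)c1`, has not yet been measured. It differs from compound 1 in one place: ((isopropylcarbonyl)oxy)methyl in place of isopropyl on an oxygen next to a carbonyl group. Among the measured compounds shown here, since no result is reported for compound 1, no measured step leads to compound 4, and the expectation rests on compound 2 and compound 3 alone. Both of those, each carrying two ester groups, gave nothing remaining in this assay, which points to a low reading for a compound carrying an ((isopropylcarbonyl)oxy)methyl ester. Compound 4 is therefore expected to give 5%, with a range from 0% to 30%.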

Compound 4, percent of the compound remaining in the plasma assay: 0%
Compound 4: middle estimate off by 5 percentage points, on the high side, and the stated range covers the measured number.
By their numbers in the plasma assay, from the lowest: compounds 2, 3 and 4 (each within the scatter of the next).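

In a physicochemical assay for metabolic stability, read by LC-MS, in phosphate buffer, with a stated time of 3 h, at pH 7.4, tested at 50 uM (on this read-out lower numbers stand for a less stable compound and higher numbers for a more stable compound), compound 1 gives > 95%, which is a limit of the assay. In the physicochemical assay compound 4 gives > 95%, also a limit. Among the compounds shown here, no new step can therefore be read between compound 1 and compound 4: the limit of > 95% in the physicochemical assay, at which 2 of the 2 values shown sit. The compounds shown leave open what ((isopropylcarbonyl)oxy)methyl in place of isopropyl does in the plasma assay.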